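Methoxy in place of hydroxy on the ester of compound 1

The compounds below may be only part of what the source reports. "The series", "measured", "known", "first", "only" and "open" are said of these compounds alone.

Compound 1 `CC1=C[C@H](OC(=O)c2ccc(O)cc2)[C@@H]2[C@](C)(CC[C@@]2(O)C(C)C)CC1=O` is the anchor of the series. Among the measured compounds shown here, in a functional assay on HL-60 cells (Homo sapiens) for cytotoxicity, read by MTT assay, with a stated time of 72 h (on this read-out higher numbers stand for weaker inhibition and lower numbers for stronger inhibition), compound 1 gives 82500 nM, the only actual number recorded so far. Compound 2 `C/C=C(\C)C(=O)O[C@H]1C[C@@]2(C)O[C@H]2[C@@H](OC(C)=O)[C@@]2(C)CC[C@@](O)(C(C)C)[C@H]12` returns only a limit of this assay, > 100000 nM. The other entry is summarised as the limit of > 100000 nM in this assay, at which 1 of the 2 values shown sits. For the measured compounds named here, no pair of measured compounds differs in a single place, so no measured effect of one change can be quoted. Compound 3 `COc1ccc(C(=O)O[C@H]2C=C(C)C(=O)C[C@@]3(C)CC[C@@](O)(C(C)C)[C@H]23)cc1` differs from compound 1 by methyl in place of hydrogen on an oxygen on an aromatic ring. The step of a 1.1-fold higher number from compound 1 to compound 3 (0.04 log units; within the scatter) is expected to stay within the usual scatter, in either direction. For compound 3 the estimate is 90000 nM, with a range from 40000 nM to 200000 nM.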

Compound 3, half-maximal inhibitory concentration: 38900 nM
For compound 3 the middle estimate is 2.3-fold (0.36 log units) above the measured one; the measured number lies below the stated range.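

In this assay, methyl in place of hydrogen on the oxygen of the 4-hydroxyphenyl ester gives a 2.1-fold lower number from compound 1 to compound 3 (0.33 log units; beyond the scatter), the first measured effect of a single change in this series. The free hydroxy of compound 1 is therefore not required for its cytotoxicity here, and the 4-methoxyphenyl ester of compound 3 is tolerated. Among the compounds shown here, nothing measured so far bears on why the number changes.

Still open, from the compounds shown here alone, is whether a longer chain on that oxygen, such as ethoxy, or an amine in place of the hydroxy, would shift the number again.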